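A Fluorinated Phenyl Replaces Bromine on a Fused Core

The compounds below may be only part of what the source reports. "The series", "measured", "known", "first", "only" and "open" are said of these compounds alone.

Compound 1 `Brc1cn2ccnc2c(-c2ccc3ncn(C4CCCCC4)c3c2)n1` was tested in a functional assay on MDA-MB-231 cells (Homo sapiens) for inhibition, read by sulforhodamine B assay, with a stated time of 48 h, tested at 10 uM (a higher number here means more inhibition at the concentration tested (going by the name of the read-out), a lower number less inhibition), where compound 1 gives 24.2%. Among the compounds with values here, of the two compounds measured so far, compound 1 has the lower number; its only neighbour is compound 2 `c1ccc(-c2cn3ccnc3c(-c3ccc4ncn(C5CCCCC5)c4c3)n2)cc1`, which in this assay gives 41.5%. Within the data shown here, the single measured step, a number 17.3 percentage points higher from compound 1 to compound 2 (beyond the scatter), is a modest rise that lies beyond the scatter.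

Compound 3 `Fc1ccccc1-c1cn2ccnc2c(-c2ccc3ncn(C4CCCCC4)c3c2)n1` has not yet been measured. It differs from compound 1 in one place: 2-fluorophenyl in place of bromo on an aromatic carbon. Among the measured compounds shown here, the closest precedent is the measured step of a number 17.3 percentage points higher from compound 1 to compound 2 (beyond the scatter), in which a phenyl ring entered at the same aromatic carbon in place of the bromo. For the measured compounds named here, the 2-fluorophenyl entering here is that phenyl carrying one fluorine, and no measured pair shows what the fluorine alone does, so the phenyl step is the only guide. A rise of about the same size is therefore expected for compound 3, a number 15.8 percentage points higher from compound 1 to compound 3 (beyond the scatter), with nothing to suggest a larger or smaller move. Compound 3 is estimated to give 40% in this assay, with a range from 25% to 55%.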

Compound 3, a percentage reported as inhibition, at one concentration (the size of the read-out at that concentration, not a potency): 21.3%
The estimate for compound 3 lay 18.7 percentage points above the measured number, outside the stated range (below it).
By their numbers in this assay, from the lowest: compounds 3 and 1 (each within the scatter of the next); then compound 2.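

At this aromatic carbon in this assay, the gain that came with phenyl does not carry over to 2-fluorophenyl: the change from bromo gives a number 2.9 percentage points lower from compound 1 to compound 3 (within the scatter) and so leaves the two compounds indistinguishable in this read-out. The phenyl ring alone therefore does not secure the gain, and a single fluoro in place of hydrogen on that ring, with a number 20.2 percentage points lower from compound 2 to compound 3 (beyond the scatter) as a modest step, is enough to cancel it. Nothing available explains why this fluorine has such an effect.

The compounds shown leave open whether the loss belongs to fluorine at this particular place on the phenyl ring or would also follow with fluorine elsewhere on it, as in 4-fluorophenyl, or with a different group there, such as methoxy, an amine or a carboxylic acid. They also leave open whether a group other than an aromatic ring at this carbon, such as a morpholine or a short alkyl chain, would match or pass compound 2 at 41.5% in this assay.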